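Swapping a small amine for a ring on the side chain

The compounds below may be only part of what the source reports. "The series", "measured", "known", "first", "only" and "open" are said of these compounds alone.

Of the compounds shown here, three sharing one core have been measured in a functional assay on MDA-MB-468 cells (Homo sapiens) for cytotoxicity, read by sulforhodamine B assay, with a stated time of 48 h; a higher number here means a weaker inhibitor of growth, a lower number a stronger inhibitor of growth. Compound 1 `Cc1ccc2nc(/N=C3\C(=O)N(CN4CCCCC4)c4ccccc43)sc2c1` gives 65600 nM. Within the data shown here, compound 2 `Cc1ccc2nc(/N=C3\C(=O)N(CN4CCCCC4)c4cccc(Br)c43)sc2c1` gives 24000 nM; the only difference from compound 1 is a 2.7-fold lower number from compound 1 to compound 2 (0.44 log units; beyond the scatter). Compound 3 `Cc1ccc2nc(/N=C3\C(=O)N(CN(C)C)c4cccc(Cl)c43)sc2c1` gives 28100 nM, the second highest of the three numbers: it stands close to compound 2, within the scatter, and clearly higher than compound 1, beyond the scatter.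

Compound 4 `Cc1ccc2nc(/N=C3\C(=O)N(CN4CCCCC4)c4cccc(Cl)c43)sc2c1` has not yet been measured. It differs from compound 3 in one place: piperidin-1-yl in place of dimethylamino on a saturated chain carbon bound to an amide-type nitrogen in a ring. Among the measured compounds shown here, no measured pair differs by exactly this change, so no single step speaks to it directly. Compound 2 and compound 3 differ in two places, including this one, and their numbers lie within the scatter of each other. For the measured compounds named here, the only measured step concerns a halogen, not the side chain. The expectation is therefore a step of a 1.1-fold lower number from compound 3 to compound 4 (0.05 log units; within the scatter) in this assay, none beyond the scatter. Compound 4 is estimated at 25000 nM, within a range of 12000 nM to 50000 nM.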

Compound 4, concentration for 50% growth inhibition: 19800 nM
Beside the measured number, compound 4's estimate is 1.3-fold (0.10 log units) above it; the measured number falls inside the stated range.
By their numbers in this assay, from the lowest: compounds 4, 2 and 3 (each within the scatter of the next); then compound 1.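

In this assay, the side chain now has a direct test: piperidin-1-yl in place of dimethylamino on a saturated chain carbon bound to an amide-type nitrogen in a ring gives (a 1.4-fold lower number from compound 3 to compound 4 (0.15 log units; within the scatter)), so with chloro on the core, this ring and the smaller open-chain amine cannot be told apart. Among these compounds, the halogen gains a comparison too, since chloro in place of bromo gives (a 1.2-fold lower number from compound 2 to compound 4 (0.08 log units; within the scatter)), whereas chloro in place of hydrogen gives (a 3.3-fold lower number from compound 1 to compound 4 (0.52 log units; beyond the scatter)), so only the step from hydrogen lies beyond the scatter. No measurement shown here explains these numbers.

Going by these compounds, it remains open whether morpholin-4-yl, with oxygen in the ring, would read like piperidin-1-yl on the same chain carbon. Fluoro or methoxy on the aromatic carbon that carries chloro also remains untested among these compounds.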